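Heteroaryl ether variation in the shared core

A few compounds are considered here, and "the series" means these few. Any claim that something is new, unique, unknown or untested is made for them only; others in the source may bear on it.

For the measured compounds named here, compound 3 `CC(C)[C@H](NC(=O)COc1cccc2ccccc12)C(=O)N[C@@H](CC(=O)O)C(=O)COc1ccnc(C(F)(F)F)n1` gives 37000 nM in a functional assay on Jurkat cells (Homo sapiens) for inhibition (a higher number here means a weaker inhibitor, a lower number a stronger inhibitor), and is one of only two compounds here with a number rather than a limit; the other, compound 1 `CC(C)[C@H](NC(=O)COc1cccc2ccccc12)C(=O)N[C@@H](CC(=O)O)C(=O)COc1cc(C(F)(F)F)n(C)n1`, gives 46000 nM, a gap within the scatter. Compound 2 `CC(C)[C@H](NC(=O)COc1cccc2ccccc12)C(=O)N[C@@H](CC(=O)O)C(=O)COc1nc2ccccc2[nH]1` is reported only as a limit of this assay, > 200000 nM (the limit of > 200000 nM in this assay, at which 1 of the 3 values shown sits). Compound 4 `CC(C)[C@H](NC(=O)COc1cccc2ccccc12)C(=O)N[C@@H](CC(=O)O)C(=O)COc1nncc(Cl)c1Cl` carries 4,5-dichloropyridazin-3-yl in place of 2-(trifluoromethyl)pyrimidin-4-yl on an oxygen on a saturated carbon. Going by the values given here, two measured steps bear on such ether swaps: a 1.2-fold lower number from compound 1 to compound 3 (0.09 log units; within the scatter) stayed within the scatter, whereas an at least 5.4-fold lower number from compound 2 to compound 3 (0.73 log units; beyond the scatter) was a clear shift away from the benzimidazole ether. Since the new group is again one six-membered aromatic ring with two hetero atoms, the expected step is a 1.1-fold higher number from compound 3 to compound 4 (0.03 log units; within the scatter), none beyond the scatter. Compound 4 is therefore estimated at 40000 nM, within 14000 nM to 120000 nM.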

Compound 4, half-maximal inhibitory concentration: > 200000 nM
Compound 4: no number, only a limit; the forecaster's own chance of this, stated with the estimate: 20%; middle value at least 5.0-fold (0.69 log units) away from the limit.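

In this assay, sharing one six-membered aromatic ring with 2 hetero atoms does not carry activity over at this ether position: an at least 5.4-fold higher number from compound 3 to compound 4 (0.73 log units; beyond the scatter). The 4,5-dichloropyridazin-3-yl group also falls away from the pyrazole ether, an at least 4.3-fold higher number from compound 1 to compound 4 (0.63 log units; beyond the scatter). The step between compound 2 and compound 4 cannot be read, since both are limits: the limit of > 200000 nM in this assay, at which 2 of the 4 values shown sit.

No compound shown separates the effect of the two chlorines from that of the pyridazine ring. An amine on the pyridazine in place of the chlorines remains an open comparison.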